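Alkynyl ether of the shared core against a smaller ether

The compounds below may be only part of what the source reports. "The series", "measured", "known", "first", "only" and "open" are said of these compounds alone.

Three ethers of the shared core have been measured in a functional assay on HL-60 cells (Homo sapiens) for inhibition, read by MTT assay, with a stated time of 72 h; a lower number here means a stronger inhibitor, a higher number a weaker inhibitor. Compound 1 `C#CCCO[C@@H]1C=CC(=O)[C@@H](CO)O1` gives 2500 nM and stands lowest of the three numbers. Compound 2 `O=C1C=C[C@@H](OC2CCCCC2)O[C@@H]1CO` gives 13300 nM, a higher number than compound 1 by a step beyond the scatter. Compound 3 `O=C1C=C[C@@H](OCc2ccccc2)O[C@@H]1CO` gives 27300 nM, the highest of the three and again beyond the scatter from compound 1.

The next compound, compound 4 `CCO[C@@H]1C=CC(=O)[C@@H](CO)O1`, is not yet measured in this assay. It differs from compound 1 in one place: hydrogen in place of ethynyl on a saturated chain carbon, two bonds along the chain from an oxygen on a saturated carbon. Going by the values given here, no measured pair shows this change, so its size is open. Among the compounds with values here, what the three numbers show is only that compound 1, with the but-3-yn-1-yl ether, reads lower than compound 2 and compound 3.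

Compound 4 is expected to stay near compound 1, with a step of a 1.6-fold higher number from compound 1 to compound 4 (0.20 log units; within the scatter) that is small and, if anything, toward a higher number. The estimate for compound 4 in this assay is 4000 nM, within a range of 1500 nM to 12000 nM.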

Compound 4, half-maximal inhibitory concentration: 3500 nM
Beside the measured number, compound 4's estimate is 1.1-fold (0.06 log units) above it, and the stated range covers the measured number.
By their numbers in this assay, from the lowest: compounds 1 and 4 (each within the scatter of the next); then compound 2; then compound 3.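

In this assay, putting hydrogen in place of ethynyl on a saturated chain carbon, two bonds along the chain from an oxygen on a saturated carbon, gives a 1.4-fold higher number from compound 1 to compound 4 (0.15 log units; within the scatter). For this one pair, the terminal triple bond can therefore be lost with no change beyond the scatter, so the number of compound 1 does not depend on the ethynyl group, and the ethyl ether of compound 4 serves equally well at this place. Nothing shown gives a reason for this result.

The compounds shown leave open whether a longer saturated chain, or a chain ending in an amine or a carboxylic acid, would hold the number at this place. A single pair also cannot say whether hydrogen in place of ethynyl would read the same on another ether of the shared core.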